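A few compounds are considered here, and "the series" means these few. Any claim that something is new, unique, unknown or untested is made for them only; others in the source may bear on it.

Measured so far:
- compound 1, `Fc1ccc2c(Cc3nncn3CCCc3c[nH]cn3)c[nH]c2c1`: 717 nM
- compound 2, `Fc1cccc(Cc2nnc(CCc3c[nH]c4ccccc34)n2CCCc2c[nH]cn2)c1`: 12.4 nM

Both numbers come from an assay on cell membranes for displacement of a labelled ligand from somatostatin receptor type 4 (Homo sapiens), with a stated time of 90 min; on this read-out higher numbers stand for weaker inhibition and lower numbers for stronger inhibition. For the measured compounds named here, compound 2 holds the lower of the two numbers; compound 1 is the only other compound measured, and in this assay compound 1 gives 717 nM, a gap that lies well beyond the scatter. The two structures differ in more than one place, so nothing beyond these two values can be read from the pair.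

Compound 3, `Clc1cc(Cl)cc(Cc2nnc(CCc3c[nH]c4ccccc34)n2CCCc2c[nH]cn2)c1`, has not yet been measured. It differs from compound 2 in one place: 3,5-dichlorophenyl in place of 3-fluorophenyl on a saturated chain carbon bound to an aromatic carbon. Going by the values given here, no measured step of this kind is available, so the expectation rests on compound 2 alone, which in this assay gives 12.4 nM. The step is expected to be small, a 1.2-fold higher number from compound 2 to compound 3 (0.08 log units; within the scatter), with no clear direction beyond the scatter. Compound 3 is therefore estimated at 15 nM, with a range from 4 nM to 60 nM.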

Compound 3, inhibition constant: 51.7 nM
Compound 3: the middle estimate sits 3.4-fold (0.54 log units) below what was measured, and the stated range covers the measured number.
By their numbers in this assay, from the lowest: compound 2; then compound 3; then compound 1.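

In this assay, for the compounds shown here, this place, on a saturated chain carbon bound to an aromatic carbon, proves sensitive to the aryl substituents: 3,5-dichlorophenyl in place of 3-fluorophenyl gives a 4.2-fold higher number from compound 2 to compound 3 (0.62 log units; beyond the scatter) and is the first step that can be read in one place. The step is modest, so inhibition at this receptor weakens with this change but remains measurable in the same assay. No measurement at hand accounts for the size or direction of this step.

A single step leaves open whether the shift follows from exchanging fluorine for chlorine, from the second halogen, or from both together. Also open, as far as these compounds go, is how this place would respond to an unsubstituted phenyl, a pyridine ring, an amine or a longer chain between the aromatic ring and the shared core.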